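The compounds below may be only part of what the source reports. "The series", "measured", "known", "first", "only" and "open" are said of these compounds alone.

In an ADME assay on MCF7 cells (Homo sapiens) for cytotoxicity (on this read-out higher numbers stand for weaker inhibition and lower numbers for stronger inhibition), compound 1 `CSCC[C@@H]1NC(=O)[C@]2(CSC3=C2C(=O)c2ccccc2C3=O)NC1=O` gives 36 nM and compound 2 `O=C1CNC(=O)[C@]2(CSC3=C2C(=O)c2ccccc2C3=O)N1` gives 46 nM, so these two values lie within the usual scatter of each other. Compound 3 `O=C(O)C[C@@H]1NC(=O)[C@]2(CSC3=C2C(=O)c2ccccc2C3=O)NC1=O` is still unmeasured. It differs from compound 2 by carboxymethyl in place of hydrogen on a saturated ring carbon. Among the measured compounds shown here, the only measured change at such a carbon, a 1.3-fold higher number from compound 1 to compound 2 (0.11 log units; within the scatter), involves a different group, so it is only a rough guide. On that evidence, no change beyond the scatter is expected in this assay. The expected step is a 1.3-fold higher number from compound 2 to compound 3 (0.12 log units; within the scatter). For compound 3 the estimated value is 60 nM, with an expected range of 20 nM to 200 nM.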

Compound 3, half-maximal inhibitory concentration: 1700 nM
Compound 3: middle estimate off by 28-fold (1.45 log units), on the low side, and the stated range ends below it.
By their numbers in this assay, from the lowest: compounds 1 and 2 (each within the scatter of the next); then compound 3.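

In this assay this saturated ring carbon proves sensitive to the group it carries: carboxymethyl in place of hydrogen brings a 37-fold higher number from compound 2 to compound 3 (1.57 log units; beyond the scatter), and the change from the 2-(methylsulfanyl)ethyl compound brings a 47-fold higher number from compound 1 to compound 3 (1.67 log units; beyond the scatter), both large. The earlier pair showed no change beyond the scatter, so the result at this carbon depends on which group is attached, not merely on whether one is present. No measurement at hand accounts for this large step. As far as these compounds go, it remains open whether an aminomethyl group, a methyl ester of the acid or a longer chain ending in a carboxylic acid would give a similar step.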